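Swapping a nitrile for an acetamide on the sulfonyl aryl ring

The compounds below may be only part of what the source reports. "The series", "measured", "known", "first", "only" and "open" are said of these compounds alone.

Measured so far:
compound 1 `N#Cc1ccc(S(=O)(=O)N2C/C(=C\c3cccc(F)c3)C(=O)/C(=C/c3cccc(F)c3)C2)cc1` gives 4500 nM
compound 2 `CC(=O)Nc1ccc(S(=O)(=O)N2C/C(=C\c3cccc(F)c3)C(=O)/C(=C/c3cccc(F)c3)C2)cc1` gives 10300 nM
compound 3 `N#Cc1ccc(S(=O)(=O)N2C/C(=C\c3ccc(F)cc3)C(=O)/C(=C/c3ccc(F)cc3)C2)cc1` gives 15000 nM

Three compounds share a sulfonyl-linked core carrying two fluorophenyl arms and were tested in a functional assay on SMMC-7721 cells (Homo sapiens) for cytotoxicity, read by MTT assay, with a stated time of 24 h; a higher number here means a weaker inhibitor, a lower number a stronger inhibitor. In this assay compound 1 gives 4500 nM, and compound 2, which differs by acetamido in place of cyano on an aromatic carbon, gives 10300 nM. The step of a 2.3-fold higher number from compound 1 to compound 2 (0.36 log units; beyond the scatter) is modest but lies beyond the usual scatter. Compound 3 gives 15000 nM; the difference between the core of compound 3 and the core of compound 1 is not broken down here. The values of compound 3 and compound 2 lie within the scatter of each other, while compound 3 stands beyond the scatter from compound 1.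

Compound 4 `CC(=O)Nc1ccc(S(=O)(=O)N2C/C(=C\c3ccc(F)cc3)C(=O)/C(=C/c3ccc(F)cc3)C2)cc1` has not yet been measured. It differs from compound 3 by acetamido in place of cyano on an aromatic carbon, the same change that separates compound 1 from compound 2, made at the same place on the ring. Among the measured compounds shown here, only one earlier instance of this change exists, so any expectation rests on it alone. Next to the measured 2.3-fold higher number from compound 1 to compound 2 (0.36 log units; beyond the scatter), the expected step is a 2.0-fold higher number from compound 3 to compound 4 (0.30 log units; within the scatter), which rests on that single precedent and on compound 3 already standing at the high end of the three numbers. Compound 4 is therefore expected to give about 30000 nM, with a likely range from 15000 nM to 60000 nM.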

Compound 4, half-maximal inhibitory concentration: 9800 nM
Compound 4: the middle estimate sits 3.1-fold (0.49 log units) above what was measured; the measured number lies below the stated range.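

In this assay, putting 4-acetamidophenyl in place of 4-cyanophenyl on the core of compound 3 gives a 1.5-fold lower number from compound 3 to compound 4 (0.18 log units; within the scatter), so this pair cannot be told apart, whereas the same change on the core of compound 1 gave a step beyond the scatter. The change therefore did not carry from one core to the other with the same effect, and the gap between the two steps is itself larger than the scatter allows: the same change on two cores in this assay, a 2.3-fold higher number (0.36 log units; beyond the scatter) from compound 1 to compound 2 and a 1.5-fold lower number (0.18 log units; within the scatter) from compound 3 to compound 4, 3.5-fold (0.54 log units) apart, beyond the scatter of two such steps. This shows that, for these two pairs, the step measured on one core was not a reliable guide to the step on the other, but it does not show which feature of the cores accounts for the difference, and two pairs give no rule for any further core in the series.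

The compounds shown carry only the nitrile and the acetamide on the sulfonyl aryl ring, so it remains open how an amine, a carboxylic acid or a methoxy group at that place would read on either core. As far as these compounds go, it also remains open whether the change would behave in the same way on a core whose two arms carry chlorine instead of fluorine.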